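The source may report more compounds than this note shows. Statements on the series, on what has been measured and on what is new or still open speak of the compounds shown alone.

In a functional assay on PC-3 cells (Homo sapiens) for cytotoxicity, read by WST assay, with a stated time of 72 h (on this read-out lower numbers stand for stronger inhibition and higher numbers for weaker inhibition), compound 1 `Cc1ccc(C2(c3ccc(O)cc3)C(=O)Nc3c2ccc(F)c3F)cc1` gives 0.8 nM and compound 2 `O=C1Nc2c(ccc(F)c2F)C1(c1ccc(O)cc1)c1cccs1` gives 0.3 nM, the lower of the two numbers. Compound 3 `CCCC1(c2ccc(O)cc2)C(=O)Nc2c1ccc(F)c2F` is not yet measured. It carries propyl in place of thiophen-2-yl on a saturated ring carbon. Among the compounds with values here, the only measured step at this place is a 2.7-fold lower number from compound 1 to compound 2 (0.43 log units; beyond the scatter). That modest step exchanged one ring group for another, so it offers only weak guidance for a chain with no ring. A somewhat larger move towards a higher number seems likely, and the expected change is a 6.7-fold higher number from compound 2 to compound 3 (0.82 log units; beyond the scatter). The estimated value for compound 3 is 2 nM, with an expected range from 0.4 nM to 12 nM.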

Compound 3, half-maximal inhibitory concentration: > 1000 nM
Compound 3: a limit, no number (the forecaster's own chance of this, stated with the estimate: 3%); at least 500-fold (2.69 log units) between middle value and limit.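

Compound 3 gives no number in this assay, only a limit: the limit of > 1000 nM in this assay, at which 1 of the 3 values shown sits. At this saturated ring carbon, swapping one aromatic ring for another changed little, whereas propyl gives an at least 3300-fold higher number from compound 2 to compound 3 (3.52 log units; beyond the scatter) and an at least 1200-fold higher number from compound 1 to compound 3 (3.09 log units; beyond the scatter). Among these compounds, then, this position accepts both ring groups but loses nearly all activity with a short chain that has no ring. The compounds shown leave open whether any ring will do here, as a cyclohexyl group would test, or whether it must be aromatic. They also leave open whether a longer chain, such as hexyl, would recover any activity.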